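A pyridinyl for fluorophenyl swap at one aromatic carbon

This account rests on a few compounds, and the source may have more. Where it says the series, first, only, none or still open, it means among the compounds named here.

Two compounds share one core. Compound 1 `CC(C(=O)NCc1ccc(C(F)(F)F)cc1N1CCN(c2ccccc2)CC1)c1ccc(NS(C)(=O)=O)c(F)c1` carries a 4-phenylpiperazin-1-yl group on an aromatic carbon, and in an assay on CHO cells for antagonist activity at transient receptor potential cation channel subfamily V member 1 (Homo sapiens), read by FLIPR (on this read-out lower numbers stand for stronger inhibition and higher numbers for weaker inhibition), compound 1 gives 2 nM. Compound 2 `CC(C(=O)NCc1ccc(C(F)(F)F)cc1-c1cccc(F)c1)c1ccc(NS(C)(=O)=O)c(F)c1` carries a 3-fluorophenyl at that place, and in this assay compound 2 gives 1.9 nM. The step of a 1.1-fold lower number from compound 1 to compound 2 (0.02 log units; within the scatter) lies within the scatter, so the two values cannot be ordered; compound 2 holds the lowest of the two numbers, with compound 1 nearest at a gap that is within the scatter.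

Compound 3 `CC(C(=O)NCc1ccc(C(F)(F)F)cc1-c1cccnc1)c1ccc(NS(C)(=O)=O)c(F)c1` has not yet been measured. It differs from compound 2 in one place: pyridin-3-yl in place of 3-fluorophenyl on an aromatic carbon. Among the measured compounds shown here, the only measured step at this position, a 1.1-fold lower number from compound 1 to compound 2 (0.02 log units; within the scatter), put 3-fluorophenyl in place of 4-phenylpiperazin-1-yl without moving the number beyond the scatter. For the measured compounds named here, no measured step puts a ring with a hetero atom in place of a ring of carbon only, so the data give no direct guide for pyridin-3-yl. In this assay the expected step is small, a 1.8-fold higher number from compound 2 to compound 3 (0.27 log units; within the scatter), with a slight lean toward a higher number. Compound 3 is therefore estimated at 3.5 nM, within a range from 1 nM to 12 nM.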

Compound 3, inhibition constant: 59.4 nM
Compound 3: middle estimate off by 17-fold (1.23 log units), on the low side, outside the stated range (above it).
By their numbers in this assay, from the lowest: compounds 2 and 1 (each within the scatter of the next); then compound 3.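

In this assay, among the compounds shown here, this position turns out not to be indifferent to the group it carries: pyridin-3-yl in place of 3-fluorophenyl gives a 31-fold higher number from compound 2 to compound 3 (1.50 log units; beyond the scatter), the first step here beyond the scatter. The earlier pair had suggested a tolerant site, with a large 4-phenylpiperazin-1-yl and a smaller 3-fluorophenyl giving values within the scatter of each other, yet the replacement of 4-phenylpiperazin-1-yl by pyridin-3-yl gives a 30-fold higher number from compound 1 to compound 3 (1.47 log units; beyond the scatter), so a six-membered aromatic ring at this aromatic carbon does not by itself keep the number low. The material shown holds nothing that accounts for the size of this change.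

The compounds shown leave open whether the higher number goes with the ring nitrogen or with the loss of the fluorine, as compound 3 differs from compound 2 in both, and a plain phenyl at this place would separate the two. They also leave open whether pyridin-4-yl or pyridin-2-yl, with the nitrogen elsewhere in the ring, would behave as pyridin-3-yl does.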